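The source may report more compounds than this note shows. Statements on the series, on what has been measured and on what is new or still open speak of the compounds shown alone.

Measured so far:
- compound 1 `Cc1cc(N2CCCCC2)nc(SCc2nc3ccccc3[nH]2)n1` — in a functional assay on ECa-109 cells (Homo sapiens) for cytotoxicity, read by MTT assay, with a stated time of 72 h (on this read-out lower numbers stand for stronger inhibition and higher numbers for weaker inhibition), compound 1 gives > 100000 nM, a limit of the assay.
- compound 2 `Cc1cc(NNC(N)=S)nc(SCc2nc3ccccc3[nH]2)n1` — in this assay compound 2 gives > 100000 nM, again only a limit.

Compound 2 therefore stands at the ceiling of what this assay reports: no number is known for it, only that it lies beyond the measured range, a position it shares with compound 1 (the limit of > 100000 nM in this assay, at which 2 of the 2 values shown sit). Within the data shown here, the one measured change, a step that the two limits leave unreadable from compound 1 to compound 2, cannot be read in size because both of its ends are limits.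

Compound 3 `Cc1cc(Nc2ccc(Br)cc2)nc(SCc2nc3ccccc3[nH]2)n1` is the next compound to be tested. It differs from compound 2 in one place: a group of 7 heavy atoms (6 carbon, 1 bromine; one six-membered aromatic ring of carbon only) in place of a group of 4 heavy atoms (1 carbon, 2 nitrogen, 1 sulfur; no ring), on a nitrogen on an aromatic ring. Among the measured compounds shown here, no measured step speaks to this change; the only step recorded ends at the limit on both sides and so gives no direction and no size. With nothing to push the estimate away from where compounds 1 and 2 sit, compound 3 is expected to remain near the limit, with the step of a number no higher from compound 2 to compound 3 (the limit leaves the size open) assumed to be none beyond the scatter. The estimate for compound 3 is 100000 nM, in a range from 20000 nM to 300000 nM, and it is expected that the assay may again report only a limit.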

Compound 3, half-maximal inhibitory concentration: 42900 nM
For compound 3 the middle estimate is 2.3-fold (0.37 log units) above the measured one; low and high end bracket the measured number.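

At the nitrogen on the aromatic ring, 4-bromophenyl brings the first number below the ceiling of this assay, with an at least 2.3-fold lower number from compound 2 to compound 3 (0.36 log units; beyond the scatter). The comparison with the piperidin-1-yl group at the aromatic carbon points the same way, with (4-bromophenyl)amino giving an at least 2.3-fold lower number from compound 1 to compound 3 (0.36 log units; beyond the scatter). Each of these steps starts from a limit, so its full size stays unknown, but together they show what the earlier pair could not, namely that changing the group at this place can move the read-out, while compound 3 still needs a high concentration to reach half-maximal inhibition, and the other two compounds remain at the limit: the limit of > 100000 nM in this assay, at which 2 of the 3 values shown sit.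

Whether the bromine or the phenyl ring accounts for the change stays open, and a plain phenyl group or a 4-chlorophenyl group at the same place would help to separate the two. Also open, going by these compounds, is whether the aromatic ring is needed at all, which a benzyl or cyclohexyl group on the same nitrogen could test.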